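Swapping the amide aryl group: a triazolylphenyl amide

This account rests on a few compounds, and the source may have more. Where it says the series, first, only, none or still open, it means among the compounds named here.

Measured compounds:
- compound 1, `CCCN(CC[C@H]1CC[C@H](NC(=O)/C=C/c2ccc(Cl)cc2)CC1)[C@H]1CCc2nc(N)sc2C1`: 2.5 nM
- compound 2, `CCCN(CC[C@H]1CC[C@H](NC(=O)/C=C/c2cccc(OC)c2)CC1)[C@H]1CCc2nc(N)sc2C1`: 9.3 nM
- compound 3, `CCCN(CC[C@H]1CC[C@H](NC(=O)c2cccc3ncccc23)CC1)[C@H]1CCc2nc(N)sc2C1`: 1.6 nM

All three share one core and differ only in the group attached to the amide carbonyl carbon. In an assay on brain for displacement of a labelled ligand from D(3) dopamine receptor (Rattus norvegicus) (a higher number here means a weaker inhibitor, a lower number a stronger inhibitor), compound 3 gives 1.6 nM, the low end of the three numbers. The step of a 1.6-fold lower number from compound 1 to compound 3 (0.19 log units; within the scatter) is within the scatter, so compound 1 and compound 3 cannot be told apart, whereas a 5.8-fold lower number from compound 2 to compound 3 (0.76 log units; beyond the scatter) is beyond it, and a 3.7-fold higher number from compound 1 to compound 2 (0.57 log units; beyond the scatter) shows that exchanging one aryl group for another at this position can move the number modestly.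

Compound 4, `CCCN(CC[C@H]1CC[C@H](NC(=O)c2ccc(-n3cncn3)cc2)CC1)[C@H]1CCc2nc(N)sc2C1`, is not yet measured. It differs from compound 3 by 4-(1H-1,2,4-triazol-1-yl)phenyl in place of quinolin-5-yl on a carbonyl carbon. The two steps that bear on this change, a 1.6-fold lower number from compound 1 to compound 3 (0.19 log units; within the scatter) and a 5.8-fold lower number from compound 2 to compound 3 (0.76 log units; beyond the scatter), are both replacements at the same carbonyl carbon and both stayed modest in size. For the measured compounds named here, no measured compound carries a triazolylphenyl group, so the direction is uncertain, but a shift of similar scale is the most reasonable expectation. Compound 4 is therefore estimated at 4 nM, with a range from 1.2 nM to 15 nM, which would be expected to mean a 2.5-fold higher number from compound 3 to compound 4 (0.40 log units; beyond the scatter).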

Compound 4, inhibition constant: 2.4 nM
Compound 4: the middle estimate sits 1.7-fold (0.22 log units) above what was measured, and the stated range covers the measured number.
By their numbers in this assay, from the lowest: compounds 3, 4 and 1 (each within the scatter of the next); then compound 2.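

Placing 4-(1H-1,2,4-triazol-1-yl)phenyl on the carbonyl carbon gives a 1.5-fold higher number from compound 3 to compound 4 (0.18 log units; within the scatter) in this assay, a step within the scatter, even though the entering group has a five-membered aromatic ring with 3 hetero atoms and 3 hydrogen-bond acceptors, against the 1 hydrogen-bond acceptor of quinolin-5-yl. The comparison with the ethenyl-linked 4-chlorophenyl amide, a 1.0-fold lower number from compound 1 to compound 4 (0.02 log units; within the scatter), is also within the scatter, so three quite different groups on this carbonyl carbon now cannot be told apart by their numbers. The one exception is the 3-methoxyphenyl group on the ethenyl chain, which stays apart with a 3.9-fold lower number from compound 2 to compound 4 (0.59 log units; beyond the scatter), a step beyond the scatter, so tolerance at this position holds for compounds 1, 3 and 4 but not for compound 2.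

All the groups shown here contain aromatic rings, so it remains open whether a carboxylic acid, an amine or a plain saturated carbon chain on this carbonyl carbon would stay in the same range. Nothing available explains why such different groups give numbers this close together.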